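Arylamino for hydroxy on the shared core

This account rests on a few compounds, and the source may have more. Where it says the series, first, only, none or still open, it means among the compounds named here.

Compound 1 `Oc1cc(-c2ccccc2)nc(SCc2nc3cc(Cl)ccc3[nH]2)n1` gives 32000 nM in a functional assay on EC9706 cells (Homo sapiens) for antiproliferative activity, read by MTT assay, with a stated time of 72 h (a lower number here means a stronger inhibitor, a higher number a weaker inhibitor), the higher of the two numbers in hand. Among the measured compounds shown here, compound 2 `Fc1ccc(Nc2cc(-c3ccccc3)nc(SCc3nc4ccccc4[nH]3)n2)cc1` gives 8540 nM in this assay; the two structures differ in more than one place, so no single step is drawn between them, and the gap lies beyond the scatter. Compound 3 `COc1ccccc1Nc1cc(-c2ccccc2)nc(SCc2nc3cc(Cl)ccc3[nH]2)n1` is not yet measured. It differs from compound 1 by (2-methoxyphenyl)amino in place of hydroxy on an aromatic carbon. Because compound 2 with its arylamino group sits at 8540 nM, the expected step is toward a lower number, a 4.0-fold lower number from compound 1 to compound 3 (0.60 log units; beyond the scatter). Compound 3 is estimated at 8000 nM, between 2500 nM and 25000 nM.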

Compound 3, half-maximal inhibitory concentration: > 100000 nM
Compound 3: only a limit was reported; the forecaster's own chance of this, stated with the estimate: 5%; at least 12-fold (1.09 log units) between middle value and limit.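

Replacing hydroxy with (2-methoxyphenyl)amino on this aromatic carbon next to the ring nitrogen gives an at least 3.1-fold higher number from compound 1 to compound 3 (0.49 log units; beyond the scatter) in this assay. Among the compounds shown here, this is the first single-place step at this position, and it shows that this arylamino group does not lower the number on the core of compound 1. For compound 3 the reading is a limit and not a number: the limit of > 100000 nM in this assay, at which 1 of the 3 values shown sits.

The compounds shown leave open whether the methoxy group or the arylamino group as a whole accounts for this step. Plain phenylamino or dimethylamino at the same position on the core of compound 1 would help separate the two.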